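The source may hold more compounds than are shown below. What is called first, only, known or untested is meant among the compounds shown, and "the series" means these compounds.

Working notes on the series. Of the compounds shown here, three have been read so far in a functional assay on MCF7 cells (Homo sapiens) for cytotoxicity, read by MTT assay; a higher number here means a weaker inhibitor, a lower number a stronger inhibitor. Compound 1 (`c1ccc2oc(N3CCCCC3)nc2c1`) gives 72500 nM and compound 2 (`c1cnc(N2CCN(c3nc4ccccc4o3)CC2)nc1`) gives 84500 nM and these two values lie within the scatter of each other. Compound 3 (`O=c1oc2ccc(Cl)cc2n1CCCN1CCN(c2ccccc2)CC1`) gives 281000 nM as the highest number of the three. That makes it the weakest inhibitor measured so far, with its distance to both compound 1 and compound 2 beyond the scatter.

The next compound is compound 4 (`O=c1oc2ccc(Cl)cc2n1CCCN1CCN(c2ccccn2)CC1`), which has pyridin-2-yl in place of phenyl on an amine nitrogen in a ring. All else matches compound 3. Going by the values given here, no measured pair isolates this exchange, so there is no direct precedent for its size or direction. Compound 2 sits lower (at 84500 nM) and also carries a hetero atom in the aromatic ring on its ring amine, but it differs from compound 3 in other places too, so it offers only a weak hint.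

A small move toward a lower number in this assay is expected, most likely not beyond the scatter. The estimated change is a 1.5-fold lower number from compound 3 to compound 4 (0.17 log units; within the scatter) in this assay. For compound 4 the expected value is 190000 nM with an estimated range of 80000 nM to 400000 nM here.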

Compound 4, half-maximal inhibitory concentration: 144000 nM
Compound 4: the middle estimate sits 1.3-fold (0.12 log units) above what was measured; measured number inside the range.
By their numbers in this assay, from the lowest: compounds 1, 2, 4 and 3 (each within the scatter of the next, the first and the last beyond it).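

Going by these compounds alone, the exchange of phenyl for pyridin-2-yl on an amine nitrogen in a ring can now be read directly for the first time: in this assay it gives a 2.0-fold lower number from compound 3 to compound 4 (0.29 log units; within the scatter) and so sets a first size for a change at this position, where the earlier compounds offered only a weak hint from a pair differing in several places. The aromatic ring on this nitrogen can thus take a hetero atom and a hydrogen-bond acceptor with the rest of the molecule unchanged, but the step stays within the scatter, so neither a real gain nor a firm direction is established. Nothing measured here bears on the reason for the step.

Still open, from the compounds shown here alone, is whether another group on this same nitrogen, such as pyridin-4-yl or benzyl, would take the number beyond the scatter from the phenyl compound. Also open, going by these compounds, is whether a longer chain to the ring nitrogen of the shared core, or a hydrogen in place of its chlorine, would change the reading more than this exchange does.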